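This account rests on a few compounds, and the source may have more. Where it says the series, first, only, none or still open, it means among the compounds named here.

Compound 1 `CC(CCNC(=O)c1c(Cl)cncc1Cl)N1CCC(C(Oc2cccc(C(F)(F)F)c2)c2ccc(C(F)(F)F)cc2)CC1` carries a 3-(trifluoromethyl)phenyl on an oxygen on a saturated carbon, and in an ADME assay on PBMC cells (Homo sapiens) for cytotoxicity (a higher number here means that more compound is tolerated, a lower number that less compound is tolerated), compound 1 gives 7000 nM. Compound 2 `CC(CCNC(=O)c1c(Cl)cncc1Cl)N1CCC(C(Oc2ccccc2C(F)(F)F)c2ccc(C(F)(F)F)cc2)CC1` differs only in that ring; in this assay compound 2 gives 12500 nM, the step being a 1.8-fold higher number from compound 1 to compound 2 (0.25 log units; within the scatter). Compound 3 `CC(CCNC(=O)c1c(Cl)cncc1Cl)N1CCC(C(Oc2cccc(Cl)n2)c2ccc(C(F)(F)F)cc2)CC1` places a 6-chloropyridin-2-yl in that position. In this assay compound 3 reaches only the limit of the assay, > 32500 nM. The steps to it were an at least 4.6-fold higher number from compound 1 to compound 3 (0.66 log units; beyond the scatter) and an at least 2.6-fold higher number from compound 2 to compound 3 (0.41 log units; beyond the scatter), both of them measured only against (the limit of > 32500 nM in this assay, at which 1 of the 3 values shown sits). Compound 4 `CC(CCNC(=O)c1c(Cl)cncc1Cl)N1CCC(C(Oc2cccc(Cl)n2)c2ccc(S(C)(=O)=O)cc2)CC1` keeps that 6-chloropyridin-2-yl and changes the other ring: methylsulfonyl in place of trifluoromethyl on an aromatic carbon. Among the measured compounds shown here, none of the three measured steps touches this ring; each of them exchanges the ring on the oxygen, so no measured step bears on this change, and the shared core is otherwise untouched. With compound 3 standing at the limit, no step beyond the scatter is expected in either direction, and compound 4 is expected to sit at the limit as well, the expected step being a step that the limit leaves unreadable from compound 3 to compound 4. Compound 4 is therefore estimated at 40000 nM, with a range from 15000 nM to 100000 nM.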

Compound 4, half-maximal cytotoxic concentration: > 29500 nM
Compound 4: no number, only a limit (the forecaster's own chance of this, stated with the estimate: 70%); the middle value is on the limit's open side.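

In this assay compound 4 gives only a limit, > 29500 nM. Compound 3 and compound 4 both stand at limits, so no step between them can be read: the limit of > 29500 nM in this assay, at which 1 of the 4 values shown sits.

The compounds shown leave open whether methylsulfonyl and trifluoromethyl on that ring differ at all in this assay, with 6-chloropyridin-2-yl or any other ring on the oxygen.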